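This account rests on a few compounds, and the source may have more. Where it says the series, first, only, none or still open, it means among the compounds named here.

Measured compounds and their values:

Compound 1 `O=[N+]([O-])c1ccc(CN2CCC(n3cc(CC(OCc4cc(-c5ccccc5)no4)c4ccc(Br)cc4)nn3)CC2)cc1` – in a functional assay on MDA-MB-231 cells (Homo sapiens) for cytotoxicity, with a stated time of 48 h (on this read-out higher numbers stand for weaker inhibition and lower numbers for stronger inhibition), compound 1 gives > 25000 nM, which is a limit of the assay and not a number.
Compound 2 `O=[N+]([O-])c1ccc(CN2CCC(n3cc(CC(OCc4cc(-c5ccc(Br)cc5)no4)c4ccc(Br)cc4)nn3)CC2)cc1` – compound 2 gives > 25000 nM, again a limit rather than a number.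
Compound 3 `N#Cc1cccc(-c2cc(COC(Cc3cn(C4CCN(Cc5ccc([N+](=O)[O-])cc5)CC4)nn3)c3ccc(Br)cc3)on2)c1` – compound 3 gives > 25000 nM, also a limit.

Compound 2 therefore stands at the edge of what this assay can report; the three measured compounds all sit at the limit of > 25000 nM in this assay, at which 3 of the 3 values shown sit, so no ordering among them can be read. Compound 4 `O=[N+]([O-])c1ccc(CN2CCC(n3cc(CC(OCc4cc(-c5ccccc5Br)no4)c4ccc(Br)cc4)nn3)CC2)cc1` keeps the same atoms as compound 2, joined differently: 2-bromophenyl in place of 4-bromophenyl on an aromatic carbon.

The measured steps that touch this region of the structure are a step that the two limits leave unreadable from compound 1 to compound 2, a step that the two limits leave unreadable from compound 1 to compound 3 and a step that the two limits leave unreadable from compound 2 to compound 3; each joins two limits, so neither size nor direction is readable for any of them. Nothing measured here favours a change in either direction for compound 4. Compound 4 is expected to remain at or beyond the limit, with an estimate of 40000 nM, ranging from 15000 nM to 150000 nM. The step that the limit leaves unreadable from compound 2 to compound 4 is expected to be no more than the scatter, and most likely the assay will once more report only a limit.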

Compound 4, half-maximal inhibitory concentration: > 25000 nM
Compound 4: only a limit was reported (the forecaster's own chance of this, stated with the estimate: 85%); the middle value is on the limit's open side.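

In this assay compound 4 gives > 25000 nM, which is a limit and not a number. No step among compound 1, compound 2, compound 3 and compound 4 can be read: the limit of > 25000 nM in this assay, at which 4 of the 4 values shown sit.

The compounds shown leave open whether any change to this phenyl substituent brings a value within what this assay can report.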